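Compound 2 to compound 3: working notes

This account rests on a few compounds, and the source may have more. Where it says the series, first, only, none or still open, it means among the compounds named here.

Measured in an ADME assay on BEAS-2B cells (Homo sapiens) for cytotoxicity, read by CCK-8 assay, with a stated time of 48 h; a higher number here means a weaker inhibitor, a lower number a stronger inhibitor
compound 1 `C=CC(=O)Nc1cccc(Oc2nc(Nc3ccc(N4CCN(C)CC4)c(OC)c3)nc3[nH]ccc23)c1` | 9890 nM
compound 2 `C=CC(=O)Nc1cccc(Oc2nc(Nc3ccc(N4CCN(C)CC4)c(N)c3)nc3c2ccn3COC(=O)C(C)(C)C)c1` | 9540 nM

In this assay compound 2 at 9540 nM lies within the scatter of compound 1 at 9890 nM and no order can be read between them. Compound 3 `C=CC(=O)Nc1cccc(Oc2nc(Nc3ccc(N4CCN(C)CC4)c(N)c3)nc3[nH]ccc23)c1` differs from compound 2 by hydrogen in place of (((tert-butyl)carbonyl)oxy)methyl on an aromatic nitrogen with hydrogen in place of (((tert-butyl)carbonyl)oxy)methyl on an aromatic nitrogen. Among the compounds with values here, no measured step isolates this change. Within the data shown here, compound 1 also has hydrogen on that nitrogen, though it differs elsewhere, and stands at 9890 nM as the only guide. In this assay no step beyond the scatter is expected, in either direction, and the estimate means a 1.1-fold lower number from compound 2 to compound 3 (0.03 log units; within the scatter) as the expected step. For compound 3 the estimated value is 9000 nM with an expected range from 4500 nM to 18000 nM for now.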

Compound 3, half-maximal inhibitory concentration: 7800 nM
The estimate for compound 3 lay 1.2-fold (0.06 log units) above the measured number, and the stated range covers the measured number.
By their numbers in this assay, from the lowest: compounds 3, 2 and 1 (each within the scatter of the next).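

Hydrogen in place of (((tert-butyl)carbonyl)oxy)methyl on the aromatic nitrogen now has its own step in this assay, a 1.2-fold lower number from compound 2 to compound 3 (0.09 log units; within the scatter), so this exchange alone gives no reading beyond the scatter. Amino in place of methoxy on an aromatic carbon, with hydrogen on that nitrogen, also stays within the scatter: a 1.3-fold lower number from compound 1 to compound 3 (0.10 log units; within the scatter). Nothing at hand bears on the cause of either step.

Among the compounds shown, that nitrogen carries only hydrogen or (((tert-butyl)carbonyl)oxy)methyl, so the reading with a methyl group or a longer alkyl chain remains open. The aromatic carbon carries only amino or methoxy, which leaves a hydroxyl group or a fluorine atom there open as well.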